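A few compounds are considered here, and "the series" means these few. Any claim that something is new, unique, unknown or untested is made for them only; others in the source may bear on it.

Of the compounds shown here, two with the same thiosemicarbazone-type framework have so far been measured for their power to hold back the growth of breast-cancer cells. In a functional assay on MCF7 cells (Homo sapiens) for cytotoxicity, read by MTT assay, with a stated time of 72 h, tested at 10 uM (a lower number here means less inhibition of growth, a higher number more inhibition of growth at the concentration tested), compound 1 `Cc1ccnc(/C(N)=N/NC(=S)N2CCSCC2)c1` gives 62.5%. Compound 2 `N/C(=N\NC(=S)N1CCCC1)c1ccccn1` carries a different ring on the thiourea end and lacks the methyl group of compound 1; in this assay compound 2 gives 51.7%. Of these two numbers, that of compound 2 is the lower one, and compound 1 lies a distance above it that goes beyond the usual scatter of the method; since the two structures differ in two places at once, nothing can be said about which difference carries that gap.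

Compound 3 `Cc1ccnc(/C(N)=N/NC(=S)N2CCCC2)c1` has not yet been measured. It keeps the ring of compound 2 and differs from it in one place: methyl in place of hydrogen on an aromatic carbon. In this assay, compound 3 is expected to show a step of a number 6.3 percentage points higher from compound 2 to compound 3 (within the scatter), a modest rise that may or may not clear the scatter. The estimate for compound 3 is therefore 58%, within a range from 45% to 70%.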

Compound 3, percent growth inhibition at one concentration: 63.6%
The estimate for compound 3 lay 5.6 percentage points below the measured number; measured number inside the range.
By their numbers in this assay, from the lowest: compound 2; then compounds 1 and 3 (each within the scatter of the next).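

In this assay, methyl in place of hydrogen on an aromatic carbon, opposite the ring nitrogen, gives a step of a number 11.9 percentage points higher from compound 2 to compound 3 (beyond the scatter), so this one small change alone is enough to move the number beyond the scatter, at least with pyrrolidin-1-yl on the thiocarbonyl carbon. With the methyl in place, pyrrolidin-1-yl in place of thiomorpholin-4-yl gives a number 1.1 percentage points higher from compound 1 to compound 3 (within the scatter), so these two rings cannot be told apart here, and the gap that could not be assigned earlier now has a one-place comparison that points to the methyl rather than to the ring. Nothing available so far gives a reason for the methyl step.

Going by these compounds, whether an ethyl group, a methoxy group or a chlorine atom at this same place would give a similar step stays open, and so does whether a larger group would carry the rise further or reverse it. It is also open whether the methyl would give a similar step with thiomorpholin-4-yl on the thiocarbonyl carbon, since the compounds shown test it only with pyrrolidin-1-yl.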